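Trifluoromethyl for Methoxy on a Triazole Phenyl: Expected Cytotoxicity

The compounds below may be only part of what the source reports. "The series", "measured", "known", "first", "only" and "open" are said of these compounds alone.

Compound 1, `C=C1C[C@]23C[C@@]1(O)CC[C@H]2c1ccc(OS(=O)(=O)c2ccc(C)cc2)c(C)c1[C@@H]3Cn1cc(-c2ccc(OC)cc2)nn1`: in a functional assay on HL-60 cells (Homo sapiens) for cytotoxicity, read by MTT assay, with a stated time of 4 days (a higher number here means a weaker inhibitor, a lower number a stronger inhibitor), compound 1 gives > 20000 nM, a limit of the assay.
Compound 2, `C=C1C[C@]23C[C@@]1(O)CC[C@H]2c1ccc(O)c(C)c1[C@@H]3Cn1cc(-c2ccc(OC)cc2)nn1`: compound 2 gives > 20000 nM, also a limit.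
Compound 3, `C=C1C[C@]23C[C@@]1(O)CC[C@H]2c1ccc(O)c(C)c1[C@@H]3Cn1cc(-c2ccc(F)cc2)nn1`: compound 3 gives > 20000 nM, again a limit.

Compound 1 therefore has no number of its own, only a limit, and all three measured values sit at the same place (the limit of > 20000 nM in this assay, at which 3 of the 3 values shown sit). Compound 4, `C=C1C[C@]23C[C@@]1(O)CC[C@H]2c1ccc(OS(=O)(=O)c2ccc(C)cc2)c(C)c1[C@@H]3Cn1cc(-c2ccc(C(F)(F)F)cc2)nn1`, differs from compound 1 by trifluoromethyl in place of methoxy on an aromatic carbon. The measured steps a step that the two limits leave unreadable from compound 1 to compound 2 and a step that the two limits leave unreadable from compound 2 to compound 3 both run between limits, so neither shows how large such a change can be; the second, a swap on the same aromatic carbon, is the closer comparison but is equally silent. The expected step that the limit leaves unreadable from compound 1 to compound 4 is therefore none readable. Compound 4 is estimated at 30000 nM, with a range from 10000 nM to 100000 nM, most likely reported as a limit again.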

Compound 4, half-maximal inhibitory concentration: > 20000 nM
Compound 4 was reported as a limit (the forecaster's own chance of this, stated with the estimate: 85%); the middle value is on the limit's open side.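

In this assay, for the compounds shown here, compound 4 gives > 20000 nM as a limit, just as compound 1 does, so no step between these two compounds can be read. The compounds shown leave open how strong each really is, and whether trifluoromethyl and methoxy differ at all.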